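Tying the diethylamino group into a ring

The source may hold more compounds than are shown below. What is called first, only, known or untested is meant among the compounds shown, and "the series" means these compounds.

In a functional assay on the whole organism (Abdomen, strain ddY) for inhibition, with Mus musculus as the target, with stated times of 30 min and 20 min (a lower number here means that less compound is needed, a higher number that more compound is needed for the effect), compound 1 `CCOc1c(NC)cnn(C)c1=O` with methylamino on an aromatic carbon of the shared core needs a dose of 55 mg/kg for the half-maximal effect. Compound 2 `CCOc1c(N(C)C)cnn(C)c1=O` with dimethylamino at that place gives 86 mg/kg on the same scale. Compound 3 `CCOc1c(N(CC)CC)cnn(C)c1=O` with diethylamino gives 70 mg/kg on that scale too. These three numbers all lie within the usual scatter of one another, so compound 3 holds no firm rank among them.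

Compound 4 `CCOc1c(N2CCCC2)cnn(C)c1=O` has pyrrolidin-1-yl in place of diethylamino on an aromatic carbon. The amine thus becomes part of a five-membered non-aromatic ring. For the measured compounds named here, no measured compound carries a ring at this place, so the data offer no direct guide to that feature.

The closest evidence comes from the other changes to this group. These are a 1.6-fold higher number from compound 1 to compound 2 (0.19 log units; within the scatter) and a 1.3-fold higher number from compound 1 to compound 3 (0.10 log units; within the scatter) and also a 1.2-fold lower number from compound 2 to compound 3 (0.09 log units; within the scatter) in the same test. Each of these steps stays within the scatter, so no step beyond the scatter is expected in this assay here. The expected step is no change at the digits printed from compound 3 to compound 4 (within the scatter) by this estimate. For compound 4 the estimated dose is 70 mg/kg with an expected range of 38 mg/kg to 125 mg/kg in this estimate.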

Compound 4, dose for half-maximal effect: > 100 mg/kg
Compound 4: no number, only a limit; the forecaster's own chance of this, stated with the estimate: 5%; middle value at least 1.4-fold (0.15 log units) from the limit.
By their numbers in this assay, from the lowest: compounds 1, 3 and 2 (each within the scatter of the next). At a limit, above all of these: compound 4.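

The ring brings something the open-chain amines could not show, although only as a bound. In this assay the reading for compound 4 is a limit and not a number: (the limit of > 100 mg/kg in this assay, at which 1 of the 4 values shown sits). Set against the other compounds, this gives an at least 1.4-fold higher number from compound 3 to compound 4 (0.15 log units; that floor lies within the scatter) and an at least 1.1-fold higher number from compound 2 to compound 4 (0.06 log units; that floor lies within the scatter) and also an at least 1.8-fold higher number from compound 1 to compound 4 (0.25 log units; that floor lies within the scatter) as floors, and each floor lies within the scatter, so none of these steps is firmly larger than the differences among compounds 1, 2 and 3. What the result does show is that pyrrolidin-1-yl, with the same count of heavy atoms as diethylamino, gives no sign of lowering the dose needed, so tying the two ethyl groups into a five-membered ring brings no visible gain at this place on the shared core.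

The compounds shown leave open where the true dose of compound 4 lies, and so whether closing the ring costs anything real in this test. They also leave open how a piperidin-1-yl or morpholin-4-yl ring, or a longer chain on the amine nitrogen, would behave at this place.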